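Aryl swap on a shared core: from cyano to iodo

A few compounds are considered here, and "the series" means these few. Any claim that something is new, unique, unknown or untested is made for them only; others in the source may bear on it.

Measured so far:
- compound 1 `COc1cccc(-n2cc(COc3c(/C=C\C(=O)O)ccc(OC)c3CC=C(C)C)nn2)c1`: 25200 nM in a functional assay on NCI-H322 cells (Homo sapiens) for cytotoxicity, read by MTT assay, with a stated time of 24 h; on this read-out higher numbers stand for weaker inhibition and lower numbers for stronger inhibition
- compound 2 `COc1ccc(/C=C\C(=O)O)c(OCc2cn(-c3cccc(C#N)c3)nn2)c1CC=C(C)C`: 26500 nM in this assay

Compound 2 stands at the highest of the two numbers in this assay, but its nearest neighbour is compound 1, and the step of a 1.1-fold higher number from compound 1 to compound 2 (0.02 log units; within the scatter) is within the scatter, so the two compounds cannot be told apart on these data. Among the measured compounds shown here, that single step, cyano in place of methoxy on an aromatic carbon, is also the only one available to guide the next change.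

Compound 3 `COc1ccc(/C=C\C(=O)O)c(OCc2cn(-c3ccccc3I)nn2)c1CC=C(C)C` differs from compound 2 in one place: 2-iodophenyl in place of 3-cyanophenyl on an aromatic nitrogen. For the measured compounds named here, no measured step touches a 2-iodophenyl group or a change at this aromatic nitrogen, so the only bearing evidence is that the one swap already made on the same aryl group left the number within the scatter.

On that basis the step of a 1.0-fold lower number from compound 2 to compound 3 (0.01 log units; within the scatter) is expected to stay within the scatter, with no direction favoured. Compound 3 is therefore estimated at 26000 nM in this assay, within a range from 10000 nM to 65000 nM.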

Compound 3, half-maximal inhibitory concentration: 42300 nM
Compound 3: middle estimate off by 1.6-fold (0.21 log units), on the low side; low and high end bracket the measured number.
By their numbers in this assay, from the lowest: compounds 1, 2 and 3 (each within the scatter of the next).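

In this assay, putting 2-iodophenyl in place of 3-cyanophenyl on the aromatic nitrogen gives a 1.6-fold higher number from compound 2 to compound 3 (0.20 log units; within the scatter) and putting it in place of 3-methoxyphenyl gives a 1.7-fold higher number from compound 1 to compound 3 (0.22 log units; within the scatter) on the same shared core. The earlier swap only exchanged one 3-substituted phenyl group for another, whereas this change brings in iodine and, as the group names show, moves the substituent from the 3-position to the 2-position of the phenyl ring, yet compounds 1, 2 and 3 still cannot be told apart in this assay. Nothing measured here explains the size of these steps or shows whether the iodine or its new place matters more.

As far as these compounds go, all three compounds carry a substituted phenyl group on this nitrogen, so it remains open whether a phenyl ring bearing an amine or a carboxylic acid, or a longer alkyl chain in place of the phenyl ring, would give a step beyond the scatter. From the compounds shown here alone, the rest of the core is the same throughout, so what its other parts contribute to the read-out also remains open.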